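Ethoxy to trifluoromethoxy at the far end of compound 2

The compounds below may be only part of what the source reports. "The series", "measured", "known", "first", "only" and "open" are said of these compounds alone.

Compound 2 `CCOc1ccc(C(=O)Nc2cccc(NC(=O)COc3ccc4c(=O)ccoc4c3)c2)cc1` carries a 4-ethoxyphenyl amide. Among the compounds with values here, in an assay on isolated protein for inhibition of Rho-associated protein kinase 1 (Homo sapiens), read by scintillation counting, radiometric assay and 33P incorporation, with a stated time of 40 min, in the presence of a further agent that is not named here (a higher number here means a weaker inhibitor, a lower number a stronger inhibitor), compound 2 gives 17 nM, the lowest of the two numbers measured so far. Compound 1 `CCCC(=O)Nc1cccc(NC(=O)COc2ccc3c(=O)ccoc3c2)c1`, which carries a propyl group on that carbonyl carbon instead, gives 1430 nM in this assay. Within the data shown here, the single measured step, an 84-fold lower number from compound 1 to compound 2 (1.92 log units; beyond the scatter), shows how much the aryl amide matters.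

Compound 3 `O=C(COc1ccc2c(=O)ccoc2c1)Nc1cccc(NC(=O)c2ccc(OC(F)(F)F)cc2)c1` differs from compound 2 by trifluoromethyl in place of ethyl on an oxygen on an aromatic ring. Among the measured compounds shown here, the only measured step concerns the amide substituent as a whole, not the group on this oxygen, so it gives no direct guide to the change at hand. Both groups sit on the same oxygen and both keep the 4-substituted phenyl ring intact, so the step from compound 2 to compound 3 is expected to be small, a 1.5-fold higher number from compound 2 to compound 3 (0.17 log units; within the scatter), within the scatter. Compound 3 is therefore estimated at 25 nM, with a range from 8 nM to 80 nM.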

Compound 3, half-maximal inhibitory concentration: 869 nM
Compound 3: the middle estimate sits 35-fold (1.54 log units) below what was measured, outside the stated range (above it).
By their numbers in this assay, from the lowest: compound 2; then compounds 3 and 1 (each within the scatter of the next).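

In this assay, the small group on this oxygen matters about as much as the whole aryl amide did: trifluoromethyl in place of ethyl gives a large loss (a 51-fold higher number from compound 2 to compound 3 (1.71 log units; beyond the scatter)). That one change cancels nearly all the gain of the 4-ethoxyphenyl amide over the propyl amide, and the 4-(trifluoromethoxy)phenyl amide stays within the scatter of the propyl amide (a 1.6-fold lower number from compound 1 to compound 3 (0.22 log units; within the scatter)), so a phenyl ring on the amide does not by itself give the low number of compound 2. Nothing at hand explains why these two groups differ so sharply.

This single pair cannot separate the effect of the fluorine atoms from that of the chain itself. Also open, as far as these compounds go, is whether methoxy, a longer propoxy chain or a dimethylamino group in place of ethoxy would keep the low number of compound 2.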